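Swapping the ring-nitrogen substituent in a fused lactam series

The source may hold more compounds than are shown below. What is called first, only, known or untested is meant among the compounds shown, and "the series" means these compounds.

The measured compounds, all read in a functional assay on MCF7 cells (Homo sapiens) for antiproliferative activity, read by MTT assay, with a stated time of 72 h; on this read-out lower numbers stand for stronger inhibition and higher numbers for weaker inhibition:
Compound 1, `O=C1COc2ccc(-c3cnc(Cl)c(NS(=O)(=O)c4ccc(F)cc4)c3)cc2N1C1CCCCC1`, reports only a limit, > 40000 nM.
Compound 2, `COc1ccc(N2C(=O)COc3ccc(-c4cnc(Cl)c(NS(=O)(=O)c5ccc(F)cc5)c4)cc32)cc1`, gives 36000 nM.
Compound 3, `COc1ccc(N2C(=O)COc3ccc(-c4cccc(NS(=O)(=O)c5ccc(F)cc5)c4)cc32)cc1`, gives 32400 nM.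

Compound 3 holds the lowest of the two numbers, though compound 2 lies within the scatter of it. The cores of compound 2 and compound 3 differ, and that difference is not broken down here. Compound 1 sits at the assay limit, (the limit of > 40000 nM in this assay, at which 1 of the 3 values shown sits), so the step of an at least 1.1-fold higher number from compound 2 to compound 1 (0.04 log units; that floor lies within the scatter) is known only as a floor; the change behind it is cyclohexyl in place of 4-methoxyphenyl on an amide-type nitrogen in a ring.

The unmeasured compound 4, `O=C1COc2ccc(-c3cccc(NS(=O)(=O)c4ccc(F)cc4)c3)cc2N1C1CCCCC1`, carries the same change made on compound 3: cyclohexyl in place of 4-methoxyphenyl on an amide-type nitrogen in a ring. The place is identical in both pairs, so it counts as the same change. Its earlier outcome was a step of at least the floor size from compound 2 to compound 1, which ended at the limit.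

On that basis the expected step is a 1.4-fold higher number from compound 3 to compound 4 (0.14 log units; within the scatter), resting on the step of an at least 1.1-fold higher number from compound 2 to compound 1 (0.04 log units; that floor lies within the scatter) and on the value of compound 3, 32400 nM. Compound 4 is therefore estimated at 45000 nM, between 25000 nM and 90000 nM, with a fair chance that this assay again reports only a limit.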

Compound 4, half-maximal inhibitory concentration: 21400 nM
Compound 4: middle estimate off by 2.1-fold (0.32 log units), on the high side; the whole stated range lies above it.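

Where the change was read a second time, cyclohexyl in place of 4-methoxyphenyl on the amide-type nitrogen in a ring gives, in this assay, a 1.5-fold lower number from compound 3 to compound 4 (0.18 log units; within the scatter), so on this core the swap of an aromatic ring for a non-aromatic one stays within the usual scatter. This does not show that the change carries from one core to the other with the same outcome, nor does it show that the outcome differs between them: the same change on two cores in this assay, an at least 1.1-fold higher number (0.04 log units; that floor lies within the scatter) from compound 2 to compound 1 and a 1.5-fold lower number (0.18 log units; within the scatter) from compound 3 to compound 4; the limit leaves it open whether they differ. Compound 1 is reported only as a limit, not as a number: the limit of > 40000 nM in this assay, at which 1 of the 4 values shown sits.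

The compounds shown leave open whether any group on that nitrogen could move the number beyond the scatter, for instance a short chain such as ethyl, a benzyl group or a chain ending in an amine. They also leave open whether such a group would behave alike on both cores.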